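The source may hold more compounds than are shown below. What is called first, only, known or untested is meant among the compounds shown, and "the series" means these compounds.

Compound 1 `O=S(=O)(CC1=NCCO1)c1c(-c2ccccc2)nn(-c2ccccc2)c1-c1ccccc1` and compound 2 `COc1ccc(C2=NOC(c3ccc(C)cc3)C2S(=O)(=O)CC2=NCCO2)cc1` were tested in a functional assay, read by Griess assay, with a stated time of 150 min, tested at 50 ug/mL; a lower number here means a weaker effect, a higher number a stronger effect of the compound at the concentration tested. Compound 1 gives 54.5%, and compound 2 gives 61.9%; the gap between them lies within the usual scatter, so the two stand together rather than apart. Compound 3 `O=S(=O)(CC1=NCCS1)c1c(-c2ccccc2)nn(-c2ccccc2)c1-c1ccccc1` has not yet been measured in this assay. It differs from compound 1 by a group of 5 heavy atoms (3 carbon, 1 nitrogen, 1 sulfur; one five-membered non-aromatic ring with 2 hetero atoms) in place of a group of 5 heavy atoms (3 carbon, 1 nitrogen, 1 oxygen; one five-membered non-aromatic ring with 2 hetero atoms), on a saturated chain carbon bound to a sulfonyl sulfur. Among the measured compounds shown here, no measured pair shows what such a change does, so the step is expected to be none beyond the scatter. Compound 3 is therefore expected to give 55% in this assay, within 38% to 72%. This expectation amounts to a number 0.5 percentage points higher from compound 1 to compound 3 (within the scatter), a step within the scatter.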

Compound 3, a percentage reported as activity, at one concentration (the size of the read-out at that concentration, not a potency): "not active" (no number reported)
Compound 3 has no reported number here, and the estimate cannot be compared.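

Among the compounds shown here, compound 3 is reported as not active in this assay without a number, so no step from compound 1 can be read, and no evidence bears on this result. The compounds shown leave open what exchanging oxygen for sulfur in the five-membered non-aromatic ring does to this read-out.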